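This account rests on a few compounds, and the source may have more. Where it says the series, first, only, none or still open, it means among the compounds named here.

In a functional assay on A549 cells (Homo sapiens) for antiproliferative activity, read by MTT assay, with a stated time of 48 h (on this read-out higher numbers stand for weaker inhibition and lower numbers for stronger inhibition), compound 1 `O=C1Nc2ccc(Nc3ccc(F)cc3)cc2C1(O)Cc1ccccc1` gives 3000 nM, and compound 2 `O=C1Nc2ccc(Nc3ccc(Cl)cc3)cc2C1(O)Cc1ccccc1` gives 3100 nM. These two numbers lie within the usual scatter of each other, so compound 2 stands level with compound 1 and the pair cannot be ranked. The next compound, compound 3 `O=C1Nc2ccc(Nc3ccccc3Cl)cc2C1(O)Cc1ccccc1`, has the same atoms as compound 2, joined differently: 2-chlorophenyl in place of 4-chlorophenyl on a nitrogen on an aromatic ring. Put simply, it carries 2-chlorophenyl in place of 4-chlorophenyl on a nitrogen on an aromatic ring. Among the measured compounds shown here, only one measured step bears on this change, and only indirectly. That step, a 1.0-fold higher number from compound 1 to compound 2 (0.01 log units; within the scatter), puts chloro in place of fluoro on an aromatic carbon and stays within the scatter. For the measured compounds named here, it swaps one group for another rather than moving a group, so no measured pair shows what a change like that of compound 3 does. With so little to go on, no shift beyond the scatter is expected in either direction, though the uncertainty is wide. The expected change is a 1.1-fold higher number from compound 2 to compound 3 (0.05 log units; within the scatter), which would be within the scatter. For compound 3 the estimated value is 3500 nM, with an expected range of 1200 nM to 10000 nM.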

Compound 3, half-maximal inhibitory concentration: 2300 nM
For compound 3 the middle estimate is 1.5-fold (0.18 log units) above the measured one; low and high end bracket the measured number.
By their numbers in this assay, from the lowest: compounds 3, 1 and 2 (each within the scatter of the next).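

In this assay, the change from 4-chlorophenyl to 2-chlorophenyl on the nitrogen gives a 1.3-fold lower number from compound 2 to compound 3 (0.13 log units; within the scatter). Among the compounds shown here, this is the first measured case of a group being moved rather than swapped for another, and the result stays within the scatter, so compound 2 and compound 3 cannot be ranked. Set against the fluorine-bearing compound, the same holds, with a 1.3-fold lower number from compound 1 to compound 3 (0.12 log units; within the scatter), so for these compounds neither the choice of 4-fluorophenyl, 4-chlorophenyl or 2-chlorophenyl nor the place of the chlorine separates the numbers in this assay. The data shown offer no independent measurement that could explain this result.

As far as these compounds go, all three compounds carry a single halogen on this phenyl ring, so it remains open whether a plain phenyl, or one bearing a methoxy group, an amine or a carboxylic acid, would move the number beyond the scatter. From the compounds shown here alone, the shared core and its benzyl group are also the same throughout, so what a change there would do is unknown.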